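The source may hold more compounds than are shown below. What is called first, only, known or untested is meant among the compounds shown, and "the series" means these compounds.

Working notes on a set of compounds built on the shared core. Three of them have numbers in an ADME assay on L6 cells (Rattus norvegicus) for cytotoxicity, read by resazurin assay, with a stated time of 72 h; a lower number here means a stronger inhibitor, a higher number a weaker inhibitor. Compound 1 `O=C(NC(=O)c1ccccc1O)c1ccc(OC(F)(F)F)cc1` gives 84 ug/mL. Compound 2 `O=C(NC(=O)c1ccccc1O)c1cccc(CCl)c1` gives 1.8 ug/mL, and compound 3 `COc1cc(C(=O)NC(=O)c2ccccc2O)cc(OC)c1OC` gives 21 ug/mL. Compound 1 stands at the highest of the three numbers; the nearest is compound 3, and that gap is beyond the scatter, as is the larger gap to compound 2. For the measured compounds named here, no pair among the measured compounds differs in a single place, so no measured step can be drawn from them.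

Compound 4 `COC(=O)CCC(=O)Nc1ccc(C(=O)NC(=O)c2ccccc2O)cc1` has not yet been measured in this assay. It differs from compound 1 in one place: ((2-(methoxycarbonyl)ethyl)carbonyl)amino in place of trifluoromethoxy on an aromatic carbon. Going by the values given here, nothing among the measured compounds mirrors this change, so the expectation rests on the spread of the three numbers alone. Compound 1 is expected to remain the point of reference because compound 1 gives 84 ug/mL, the highest number of the three. The step of a 1.3-fold lower number from compound 1 to compound 4 (0.11 log units; within the scatter) is expected to be small, toward a somewhat lower number at most, and may well fall within the scatter. Compound 4 is estimated at 65 ug/mL, with a range from 25 ug/mL to 150 ug/mL.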

Compound 4, half-maximal inhibitory concentration: > 50 ug/mL
Compound 4 gave a limit, no number; the forecaster's own chance of this, stated with the estimate: 20%; the middle value lies beyond the limit too.
By their numbers in this assay, from the lowest: compound 2; then compound 3; then compound 1.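

In this assay, for the compounds shown here, compound 4 gives > 50 ug/mL, which is a limit and not a number, so no step from compound 1 to compound 4 can be read. The compounds shown leave open how ((2-(methoxycarbonyl)ethyl)carbonyl)amino in place of trifluoromethoxy on an aromatic carbon shifts the number in this assay.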